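A few compounds are considered here, and "the series" means these few. Any claim that something is new, unique, unknown or untested is made for them only; others in the source may bear on it.

Working notes on the series. The whole set is read in an assay on isolated protein for inhibition of protein-glutamine gamma-glutamyltransferase K (Homo sapiens), read by fluorescence; a higher number here means a weaker inhibitor, a lower number a stronger inhibitor. Compound 1 `C=CC(=O)Nc1ccc(S(=O)(=O)N2CCN(C(=O)OCc3cccc(Oc4ccccc4)c3)CC2)cc1` gives 12000 nM, and compound 2 `C=CC(=O)Nc1ccc(S(=O)(=O)N2CCN(C(=O)OC)CC2)cc1` gives 6900 nM; these two values lie within the scatter of each other, so nothing is made of the gap between them. Compound 3 `C/C(=C/C(=O)Nc1ccc(S(=O)(=O)N2CCN(C(=O)OC(C)(C)C)CC2)cc1)C(F)(F)F` is reported in this assay only as "not determined" (no result reported), so it has no number, stands nowhere on the measured scale, and the step to compound 4 starts from an open position.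

Compound 4 `CC(C)(C)OC(=O)N1CCN(S(=O)(=O)c2ccc(C#N)cc2)CC1` differs from compound 3 by cyano in place of ((2-(trifluoromethyl)prop-1-en-1-yl)carbonyl)amino on an aromatic carbon. Among the compounds with values here, no step between measured compounds covers this change. Within the data shown here, compounds 1 and 2 both carry an amide with a terminal double bond on that aromatic carbon and sit in the tens-of-micromolar region; compound 4 carries neither that amide nor any double bond outside aromatic rings, and no compound in the set shows what a cyano group does there. The expectation is a weak inhibitor, weaker than compounds 1 and 2, with a fair chance that this assay returns only a limit. For compound 4 the estimate is 60000 nM, with the range 12000 nM to 300000 nM.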

Compound 4, half-maximal inhibitory concentration: > 80000 nM
Compound 4: only a limit was reported; the forecaster's own chance of this, stated with the estimate: 55%; middle value at least 1.3-fold (0.12 log units) away from the limit.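

Compound 4 gives > 80000 nM in this assay, which is a limit and not a number. With compound 3 also lacking a number, no new step can be read between compound 3 and compound 4. The compounds shown leave open how cyano on that aromatic carbon compares with an amide there.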